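The source may hold more compounds than are shown below. What is called first, only, known or untested is meant among the compounds shown, and "the series" means these compounds.

Of the compounds shown here, three sharing one core have been tested in a functional assay on U-87MG ATCC cells for antiproliferative activity against U-87 MG (Homo sapiens), read by MTT assay, with a stated time of 48 h, tested at 10 uM; a lower number here means a stronger effect, a higher number a weaker effect of the compound at the concentration tested. Compound 1 `COc1ccc(-c2nc(C)c(C(=O)CSc3nc(-c4ccc(OC)cc4)c(C#N)c(=O)[nH]3)s2)cc1` gives 80.3%. Compound 2 `COc1ccc(-c2nc(C)c(C(=O)CSc3nc(-c4cccc(OC)c4)c(C#N)c(=O)[nH]3)s2)cc1` gives 66.7%, and compound 3 `COc1ccc(-c2nc(C)c(C(=O)CSc3nc(-c4ccc(OC)c(OC)c4)c(C#N)c(=O)[nH]3)s2)cc1` gives 57.6%. Compound 3 stands lowest of the three numbers: the step of a number 22.7 percentage points lower from compound 1 to compound 3 (beyond the scatter) is beyond the scatter, as is a number 13.6 percentage points lower from compound 1 to compound 2 (beyond the scatter), while a number 9.1 percentage points lower from compound 2 to compound 3 (within the scatter) lies within it, so compound 3 and compound 2 cannot be told apart.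

Compound 4 `COc1ccc(-c2nc(SCC(=O)c3sc(-c4ccc(Cl)cc4)nc3C)[nH]c(=O)c2C#N)cc1OC` differs from compound 3 by chloro in place of methoxy on an aromatic carbon. Among the compounds with values here, this change sits in a different part of the molecule from the methoxy variations that separate compounds 1, 2 and 3, so none of the measured steps bears directly on it. Within the data shown here, with no step of this kind measured, no movement beyond the scatter is expected, and compound 4 is estimated to give 55%, between 35% and 75%. That estimate means an expected step of a number 2.6 percentage points lower from compound 3 to compound 4 (within the scatter), a change within the scatter.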

Compound 4, a percentage reported as activity, at one concentration (the size of the read-out at that concentration, not a potency): 83.3%
Compound 4: the middle estimate sits 28.3 percentage points below what was measured; the whole stated range lies below it.
By their numbers in this assay, from the lowest: compounds 3 and 2 (each within the scatter of the next); then compounds 1 and 4 (each within the scatter of the next).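

Replacing methoxy with chloro on the six-membered aromatic ring of carbon only, para to a large group, gives a number 25.7 percentage points higher from compound 3 to compound 4 (beyond the scatter) in this assay, which here means a weaker effect. Within the data shown here, the earlier compounds differed only in the methoxy groups on the other phenyl ring, so this pair is the first sign that this position can also change the read-out, with 4-methoxyphenyl giving the stronger effect of the two. Nothing measured here explains the shift.

From the compounds shown here alone, it remains open whether the same swap would move the number as far with the other phenyl ring substituted as in compound 1 or compound 2. Also open, going by these compounds, is what a hydrogen, a fluoro, an amine or an ethoxy group would do at this position, which could show whether methoxy helps or chloro harms.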